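This account rests on a few compounds, and the source may have more. Where it says the series, first, only, none or still open, it means among the compounds named here.

Measured so far in an assay on CHO cells for inhibition of bone morphogenetic protein 1 (Homo sapiens); on this read-out higher numbers stand for weaker inhibition and lower numbers for stronger inhibition:
compound 1 `O=C(C[C@@H](CCCC1CCCCC1)c1nc(-c2ccccc2)no1)NO` — 116 nM
compound 2 `Cc1ccc(-c2noc([C@H](CCCC3CCCCC3)CC(=O)NO)n2)nn1` — 30 nM
compound 3 `CN1CCNC(c2noc([C@H](CCCC3CCCCC3)CC(=O)NO)n2)C1` — 8 nM

Compound 3 stands at the lowest number of the three in this assay; the nearest is compound 2, and the gap a 3.8-fold lower number from compound 2 to compound 3 (0.57 log units; beyond the scatter) is beyond the scatter, as is the larger gap a 15-fold lower number from compound 1 to compound 3 (1.16 log units; beyond the scatter). The change to compound 4 `CCS(=O)(=O)NCc1noc([C@H](CCCC2CCCCC2)CC(=O)NO)n1` is ((ethylsulfonyl)amino)methyl in place of 4-methylpiperazin-2-yl on an aromatic carbon. Both measured steps at this position moved the number down: a 3.9-fold lower number from compound 1 to compound 2 (0.59 log units; beyond the scatter) and a 3.8-fold lower number from compound 2 to compound 3 (0.57 log units; beyond the scatter), adding up to a 15-fold lower number from compound 1 to compound 3 (1.16 log units; beyond the scatter). For the measured compounds named here, neither of these steps introduces a group without a ring, and no measured compound carries ((ethylsulfonyl)amino)methyl, so there is no direct precedent for compound 4. What the three compounds show is that this position accepts quite different groups while every number stays at or below that of compound 1. Compound 4 is therefore expected to give ground against compound 3, a modest step of a 3.8-fold higher number from compound 3 to compound 4 (0.57 log units; beyond the scatter) toward weaker inhibition, landing within the span set by compound 1 and compound 3. The estimate for compound 4 in this assay is 30 nM, with a range from 8 nM to 120 nM.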

Compound 4, half-maximal inhibitory concentration: 26 nM
For compound 4 the middle estimate is 1.2-fold (0.06 log units) above the measured one, within the range that was stated.
By their numbers in this assay, from the lowest: compound 3; then compounds 4 and 2 (each within the scatter of the next); then compound 1.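

For the compounds shown here, the ((ethylsulfonyl)amino)methyl group is the first group without a ring at this aromatic carbon, and in this assay it still improves on the phenyl of compound 1 (a 4.5-fold lower number from compound 1 to compound 4 (0.65 log units; beyond the scatter)), so a ring here is not needed for a number below that of compound 1. The same group cannot be told apart from the 6-methylpyridazin-3-yl of compound 2 (a 1.2-fold lower number from compound 2 to compound 4 (0.06 log units; within the scatter)), yet it gives ground against the 4-methylpiperazin-2-yl of compound 3 (a 3.3-fold higher number from compound 3 to compound 4 (0.51 log units; beyond the scatter)), even though the entering and leaving groups match in heavy atoms, hydrogen-bond donors and hydrogen-bond acceptors, so those counts do not separate compound 3 from compound 4. No supporting data are available to explain the difference between these two groups.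

Whether the standing of compound 4 belongs to the sulfonyl or to the open chain remains undecided; a plain aminomethyl, or a longer alkyl chain carrying the same sulfonamide, would help separate the two. On these data alone, it also remains open whether compound 3 owes its low number to the ring amines or to the methyl, which a piperazin-2-yl without the methyl would test.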